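The source may hold more compounds than are shown below. What is called first, only, known or untested is meant among the compounds shown, and "the series" means these compounds.

Compound 2 `COc1ncc(-c2ccc3nc(NC(C)=O)nn3c2)cc1NS(=O)(=O)c1ccc(C)cc1` and compound 1 `COc1ncc(-c2ccc3nc(NC(C)=O)nn3c2)cc1NS(=O)(=O)c1ccc(F)cc1` share one core and differ only in the change (fluoro in place of methyl on an aromatic carbon). In a functional assay on MCF7 cells (Homo sapiens) for antiproliferative activity, read by MTT assay, with a stated time of 48 h (a higher number here means a weaker inhibitor, a lower number a stronger inhibitor), compound 2 gives 810 nM, and compound 1 gives 840 nM, so that this change made a 1.0-fold higher number from compound 2 to compound 1 (0.02 log units; within the scatter). Compound 3 `COc1ncc(-c2ccn3nc(NC(C)=O)nc3c2)cc1NS(=O)(=O)c1ccc(C)cc1` is built from the same atoms as compound 2, joined differently; the difference between the two cores is not broken down here. In this assay compound 3 gives 1360 nM, which against compound 1 and compound 2 lies within the scatter. Compound 4 `COc1ncc(-c2ccn3nc(NC(C)=O)nc3c2)cc1NS(=O)(=O)c1ccc(F)cc1` applies the change fluoro in place of methyl on an aromatic carbon to the core of compound 3, at a place described in the same words as before. Compound 4 is therefore expected to show a 1.0-fold lower number from compound 3 to compound 4 (0.00 log units; within the scatter), an expectation resting on a 1.0-fold higher number from compound 2 to compound 1 (0.02 log units; within the scatter). Compound 4 is estimated at 1350 nM in this assay, within 700 nM to 2700 nM.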

Compound 4, half-maximal inhibitory concentration: 1730 nM
Beside the measured number, compound 4's estimate is 1.3-fold (0.11 log units) below it, within the range that was stated.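

In this assay, fluoro in place of methyl on the second core gave a 1.3-fold higher number from compound 3 to compound 4 (0.10 log units; within the scatter), and the two steps agree: the same change on two cores in this assay, a 1.0-fold higher number (0.02 log units; within the scatter) from compound 2 to compound 1 and a 1.3-fold higher number (0.10 log units; within the scatter) from compound 3 to compound 4, 1.2-fold (0.09 log units) apart, within the scatter of two such steps So, on these two cores, the change carried over with no difference that stands clear of the scatter. This is only a weak test of transfer, since neither step is beyond the scatter, and it does not show that the agreement would hold on a third core or for a change with a larger effect.

The compounds shown leave open what a methoxy group, an amine or a carboxylic acid would do in place of the methyl or fluoro. They also leave open whether either core would respond differently to such a group.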